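Adding Two Methoxy Groups to a Cinnamamide

The compounds below may be only part of what the source reports. "The series", "measured", "known", "first", "only" and "open" are said of these compounds alone.

Compound 2 `COc1ccc(/C=C/C(=O)NCc2ccc(OCc3nc(C)c(C)nc3C)c(OC)c2)cc1` carries the lower of the two numbers in a functional assay on SH-SY5Y cells (Homo sapiens) for cytotoxicity, read by MTT assay, with stated times of 24 h and 4 h; a higher number here means that more compound is needed for the effect, a lower number that less compound is needed: compound 2 gives 5050 nM, while compound 1 `COc1cc(CNC(=O)/C=C/c2ccccc2)ccc1OCc1nc(C)c(C)nc1C` gives 7310 nM. Among the compounds with values here, the only step known so far, a 1.4-fold lower number from compound 1 to compound 2 (0.16 log units; within the scatter), is a small one. Compound 3 `COc1cc(OC)c(OC)cc1/C=C/C(=O)NCc1ccc(OCc2nc(C)c(C)nc2C)c(OC)c1` differs from compound 2 by 2,4,5-trimethoxyphenyl in place of 4-methoxyphenyl on a double-bonded chain carbon bound to a double-bonded chain carbon. Since the earlier addition of one methoxy moved this assay only within its scatter, the step of a 1.3-fold lower number from compound 2 to compound 3 (0.10 log units; within the scatter) is expected to be modest as well, perhaps toward a slightly lower number. Compound 3 is therefore estimated at 4000 nM, with a range from 1500 nM to 11000 nM.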

Compound 3, half-maximal effective concentration: 3620 nM
Compound 3: the middle estimate sits 1.1-fold (0.04 log units) above what was measured; low and high end bracket the measured number.
By their numbers in this assay, from the lowest: compounds 3, 2 and 1 (each within the scatter of the next, the first and the last beyond it).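

In this assay the step of a 1.4-fold lower number from compound 2 to compound 3 (0.14 log units; within the scatter) shows that the further methoxy groups on 2,4,5-trimethoxyphenyl cannot be told apart from 4-methoxyphenyl at this position. Set against plain phenyl, however, the same group gives a 2.0-fold lower number from compound 1 to compound 3 (0.31 log units; beyond the scatter) and so provides the first step in this series beyond the scatter, though a modest one. Nothing available explains why these numbers differ. Still open, from the compounds shown here alone, is how this double-bonded chain carbon would respond to a phenyl ring carrying an amine or a carboxylic acid instead of methoxy groups.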